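Swapping a Small Ring for a Methoxyphenyl Group

The compounds below may be only part of what the source reports. "The series", "measured", "known", "first", "only" and "open" are said of these compounds alone.

Of the compounds shown here, three have been tested in an in vitro functional assay on cells for agonist activity at Bombesin receptor subtype-3 (Homo sapiens), read by luminescence and calcium flux; a higher number here means that more compound is needed for the effect, a lower number that less compound is needed. Compound 1 `CCCCc1cnc(C(C)Cc2ccc(-c3ccccc3C(=O)O)cc2)[nH]1` gives 2760 nM, compound 2 `CCCCc1cnc(C(CCC)Cc2ccc(-c3ccccc3C(=O)O)cc2)[nH]1` gives 1180 nM, and compound 3 `O=C(O)c1ccccc1-c1ccc(CCc2ncc(CC3CCC3)[nH]2)cc1` gives 588 nM. Compound 3 has the smallest of the three numbers, but its gap to compound 2 lies within the usual scatter of the assay, and only its gap to compound 1 lies beyond it. Among the measured compounds shown here, the one single-point step among the measured compounds is a 2.3-fold lower number from compound 1 to compound 2 (0.37 log units; beyond the scatter), a change at a different part of the shared core.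

Compound 4 `COc1cccc(Cc2cnc(CCc3ccc(-c4ccccc4C(=O)O)cc3)[nH]2)c1` is built from compound 3 by one change: 3-methoxyphenyl in place of cyclobutyl on a saturated chain carbon bound to an aromatic carbon. For the measured compounds named here, no measured step touches this position, so the measured step from compound 1 to compound 2 cannot be read across to it. The expectation therefore rests on the value of compound 3 alone, and the estimated change in this assay is a 1.0-fold higher number from compound 3 to compound 4 (0.01 log units; within the scatter), with no direction beyond the scatter expected. Compound 4 is accordingly estimated at 600 nM, within a range from 150 nM to 2500 nM.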

Compound 4, half-maximal effective concentration: 4120 nM
Compound 4: the middle estimate sits 6.9-fold (0.84 log units) below what was measured, outside the stated range (above it).
By their numbers in this assay, from the lowest: compounds 3 and 2 (each within the scatter of the next); then compounds 1 and 4 (each within the scatter of the next).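

This position is not indifferent to what it carries: in this assay, 3-methoxyphenyl in place of cyclobutyl gives a 7.0-fold higher number from compound 3 to compound 4 (0.85 log units; beyond the scatter), a change beyond the scatter. Among the compounds shown here, the earlier compounds could not show this, as their one measured step lies at a different part of the shared core, so this is the only reading of how the number responds to a change here. No supporting measurement bears on why the number rises with this swap.

The compounds shown leave open whether the higher number goes with the aromatic ring or with its methoxy group, a question that plain benzyl or cyclohexylmethyl in place of 3-methoxybenzyl would help to separate. Also open, as far as these compounds go, is how a hydroxyl in place of the methoxy group would read.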